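This account rests on a few compounds, and the source may have more. Where it says the series, first, only, none or still open, it means among the compounds named here.

Among the measured compounds shown here, in a toxicity assay on HEL cells (Homo sapiens) for inhibition, read by cell counting, with a stated time of 3 days (on this read-out higher numbers stand for lower toxicity in this test and lower numbers for higher toxicity in this test), compound 2 `CCCn1cc(CN2CCCCC2)c2cc(CNc3ccc(Cl)cc3)ccc21` gives 15000 nM, the only actual number so far. Compound 1 `CCCn1cc(CN2CCCCC2)c2ccccc21` reads > 100000 nM, which is a limit of the assay and not a number. For the measured compounds named here, only one measured step bears on what follows: an at least 6.6-fold lower number from compound 1 to compound 2 (0.82 log units; beyond the scatter), with ((4-chlorophenyl)amino)methyl taking the place of hydrogen on an aromatic carbon. For compound 1 that size is a minimum, set by the limit of > 100000 nM in this assay, at which 1 of the 2 values shown sits.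

Compound 3 `CCCn1cc(CN2CCCCC2)c2cc(NC(=O)c3ccccc3)ccc21` differs from compound 2 in one place: benzamido in place of ((4-chlorophenyl)amino)methyl on an aromatic carbon. It therefore still carries a group on an aromatic carbon of the shared core, but not the group behind the measured step. Going by the values given here, no measured step compares these two groups directly, so the guide is indirect. Compound 3 is expected to keep only part of the drop seen in an at least 6.6-fold lower number from compound 1 to compound 2 (0.82 log units; beyond the scatter). The expected change in this assay is therefore a modest rise in the number, estimated as a 2.3-fold higher number from compound 2 to compound 3 (0.37 log units; beyond the scatter). For compound 3 the estimate is 35000 nM, with an expected range from 12000 nM to 100000 nM.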

Compound 3, half-maximal cytotoxic concentration: 31000 nM
Beside the measured number, compound 3's estimate is 1.1-fold (0.05 log units) above it; measured number inside the range.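

The drop from hydrogen is not tied to ((4-chlorophenyl)amino)methyl: in this assay, benzamido on the same aromatic carbon also gives an at least 3.2-fold lower number from compound 1 to compound 3 (0.50 log units; beyond the scatter). Compound 1 reads > 100000 nM, which is a limit of the assay and not a number, so the size of that step is a minimum: the limit of > 100000 nM in this assay, at which 1 of the 3 values shown sits. The two groups have the same count of heavy atoms and each holds one six-membered aromatic ring of carbon only, yet the exchange gives a 2.1-fold higher number from compound 2 to compound 3 (0.32 log units; beyond the scatter), so at this position the number depends on which group is present and not only on whether a group of this size is there.

Benzamido differs from ((4-chlorophenyl)amino)methyl both in the chlorine and in the link that joins the ring to the core, and these two compounds cannot separate those differences. A 4-chlorobenzamido group would bear on that question, while a simple amine or a carboxylic acid on this carbon would show whether the aromatic ring of the group is needed for the lower number at all.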